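Dimethylamide to Morpholine Amide in a Ketoamide Series

This account rests on a few compounds, and the source may have more. Where it says the series, first, only, none or still open, it means among the compounds named here.

Compound 2 `CN(C)C(=O)C(=O)CCc1ccc(Cl)cc1` belongs to a small set of ketoamides examined in an assay on HEK-293T cells for inhibition of phospholipase A and acyltransferase 5 (Homo sapiens), with stated times of 30 min and 20 min; a lower number here means a stronger inhibitor, a higher number a weaker inhibitor. In this assay compound 2 reaches only the limit of > 10000 nM, so its potency is not known as a number. For the measured compounds named here, its neighbour compound 1 `CCNC(=O)C(=O)CCc1ccc(Cl)cc1` gives 1000 nM in this assay, and the step of an at least 10-fold higher number from compound 1 to compound 2 (1.00 log units; beyond the scatter) is the only measured comparison; that step rests on (the limit of > 10000 nM in this assay, at which 1 of the 2 values shown sits). The next compound, compound 3 `O=C(CCc1ccc(Cl)cc1)C(=O)N1CCOCC1`, differs from compound 2 by morpholin-4-yl in place of dimethylamino on a carbonyl carbon. Going by the values given here, the entering group, like the leaving one, brings no hydrogen-bond donor, so the single measured step, which followed the loss of the ethylamino group, gives no sign that potency would return. Compound 3 is therefore expected to stay at the weak end, with a step that the limit leaves unreadable from compound 2 to compound 3 as the estimated change. Compound 3 is estimated at 20000 nM in this assay, with a range from 5000 nM to 80000 nM, and another limit would not be surprising.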

Compound 3, half-maximal inhibitory concentration: > 10000 nM
Compound 3 gave a limit, no number; the forecaster's own chance of this, stated with the estimate: 70%; the middle value lies beyond the limit too.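

At this carbonyl carbon, morpholin-4-yl in place of ethylamino gives an at least 10-fold higher number from compound 1 to compound 3 (1.00 log units; beyond the scatter), so the weak result no longer rests on dimethylamino alone. Morpholin-4-yl is a larger group than dimethylamino and carries a ring oxygen, yet neither difference brings back a numerical reading in this assay. Compound 2 and compound 3 both stand at a limit rather than a number, so the step between them cannot be read, and any difference in strength between them stays hidden: the limit of > 10000 nM in this assay, at which 2 of the 3 values shown sit.

The compounds shown leave open whether the amide hydrogen of compound 1 is what matters, or whether the size and shape of the ethylamino group also count. A methylamino or propylamino group at this carbonyl carbon would separate those two possibilities, and a piperidin-1-yl group would extend the comparison among ring amides.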